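Swapping a phenyl for methyl on a fused bicyclic urea core

This account rests on a few compounds, and the source may have more. Where it says the series, first, only, none or still open, it means among the compounds named here.

Measured compounds:
- compound 1, `CCCc1cc(NNC(=O)Nc2cc(Cl)nc(Cl)c2)nc2c1c(C)nn2C`: 2360 nM
- compound 2, `Cc1nn(C)c2nc(NNC(=O)Nc3cc(Cl)nc(Cl)c3)cc(-c3ccccc3)c12`: 5320 nM

In an assay on isolated protein for binding affinity to sphingosine 1-phosphate receptor 2 (Homo sapiens), read by surface plasmon resonance (a lower number here means tighter binding, a higher number weaker binding), compound 2 holds the highest of the two numbers, and its nearest neighbour is compound 1, which sits a 2.3-fold higher number from compound 1 to compound 2 (0.35 log units; beyond the scatter) when read from compound 1 to compound 2. The next compound, compound 3, has the structure `Cc1cc(NNC(=O)Nc2cc(Cl)nc(Cl)c2)nc2c1c(C)nn2C` and carries the change methyl in place of phenyl on an aromatic carbon on an aromatic carbon of the core shared by all three. For the measured compounds named here, only one measured step bears on it: the exchange of propyl for phenyl, which gave a 2.3-fold higher number from compound 1 to compound 2 (0.35 log units; beyond the scatter) in this assay. Methyl is a smaller group than propyl, so the move from phenyl back to a short alkyl group is expected to bring the number down again, toward the value of compound 1. Compound 3 is therefore estimated at 2800 nM in this assay, with a range from 1200 nM to 7000 nM, which corresponds to an expected step of a 1.9-fold lower number from compound 2 to compound 3 (0.28 log units; within the scatter).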

Compound 3, dissociation constant: 11000 nM
Estimate against measurement, compound 3: 3.9-fold (0.59 log units) below, outside the stated range (above it).
By their numbers in this assay, from the lowest: compound 1; then compound 2; then compound 3.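

At the position opposite the ring nitrogen, this assay shows no steady link between the size of the group and the number: methyl in place of phenyl raises it (a 2.1-fold higher number from compound 2 to compound 3 (0.32 log units; beyond the scatter)), and shortening propyl to methyl raises it by more (a 4.7-fold higher number from compound 1 to compound 3 (0.67 log units; beyond the scatter)). Methyl therefore gives the weakest binding of the three, while propyl gives the tightest and phenyl lies between them, so a short alkyl group does not simply restore the value seen with the longer chain. The data shown offer no explanation for this order.

As far as these compounds go, it remains open whether an ethyl or butyl chain would place the optimum near propyl, or whether a cyclohexyl ring would behave more like propyl or phenyl. From the compounds shown here alone, the effect of an amine or a methoxy group at this position also remains unknown.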